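The source may hold more compounds than are shown below. What is called first, only, known or untested is meant among the compounds shown, and "the series" means these compounds.

Three measured compounds share one core and differ only in the group on the sulfonamide nitrogen. In a functional assay on HT-1080 cells (Homo sapiens) for antiproliferative activity, read by sulforhodamine B assay, with a stated time of 48 h (a lower number here means a stronger inhibitor, a higher number a weaker inhibitor), compound 1 `N=C(N)NS(=O)(=O)c1ccc(N/C(S)=N\c2ccnc3cc(C(F)(F)F)ccc23)cc1` gives 24300 nM. Compound 2 `Cc1noc(NS(=O)(=O)c2ccc(N/C(S)=N\c3ccnc4cc(C(F)(F)F)ccc34)cc2)c1C` gives 27700 nM in this assay, and compound 3 `O=S(=O)(Nc1ncccn1)c1ccc(N/C(S)=N\c2ccnc3cc(C(F)(F)F)ccc23)cc1` gives 29100 nM in this assay. On the bare numbers compound 3 stands highest of the three, yet its steps to compound 1 and to compound 2 both lie within the scatter, so the three cannot be told apart. The steps among them, a 1.1-fold higher number from compound 1 to compound 2 (0.06 log units; within the scatter), a 1.2-fold higher number from compound 1 to compound 3 (0.08 log units; within the scatter) and a 1.1-fold higher number from compound 2 to compound 3 (0.02 log units; within the scatter), all come from exchanging the group on the sulfonamide nitrogen, and none reaches beyond the scatter. Compound 4 `COc1ncnc(NS(=O)(=O)c2ccc(N/C(S)=N\c3ccnc4cc(C(F)(F)F)ccc34)cc2)c1OC` has not been measured; its change from compound 3 is 5,6-dimethoxypyrimidin-4-yl in place of pyrimidin-2-yl on a sulfonamide nitrogen, again an exchange at the same place. Every such exchange so far has left this assay within the scatter, and compound 4 is therefore expected to show a 1.0-fold higher number from compound 3 to compound 4 (0.01 log units; within the scatter), no step beyond the scatter. Compound 4 is estimated at 30000 nM, with a range from 12000 nM to 75000 nM.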

Compound 4, half-maximal inhibitory concentration: 22800 nM
The estimate for compound 4 lay 1.3-fold (0.12 log units) above the measured number; the measured number falls inside the stated range.
By their numbers in this assay, from the lowest: compounds 4, 1, 2 and 3 (each within the scatter of the next).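

In this assay the exchange of pyrimidin-2-yl for 5,6-dimethoxypyrimidin-4-yl on the sulfonamide nitrogen gives a 1.3-fold lower number from compound 3 to compound 4 (0.11 log units; within the scatter) and so leaves the number in place, even though the entering group brings more heavy atoms and more hydrogen-bond acceptors. Against the other two groups, the picture is the same: the exchanges give a 1.2-fold lower number from compound 2 to compound 4 (0.08 log units; within the scatter) and a 1.1-fold lower number from compound 1 to compound 4 (0.03 log units; within the scatter) and show that the largest group seen so far at this position still cannot be told apart from the smallest. Nothing shown bears on why these numbers stay together.

As far as these compounds go, whether an acetyl group, a plain methyl or a carboxylic acid on this nitrogen would move the number beyond the scatter remains open. So does the effect of any change elsewhere on the shared core, since all four compounds keep it.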